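From Pyrimidin-2-yl to Furan-3-yl: An Expected Outcome

The compounds below may be only part of what the source reports. "The series", "measured", "known", "first", "only" and "open" are said of these compounds alone.

Compound 1 `CCN(CC)C(=O)c1ccccc1OCC1=NCCN1`: in a functional assay for activation of Alpha-1B adrenergic receptor (Homo sapiens), read by calcium flux (on this read-out higher numbers stand for an effect only at larger amounts of compound and lower numbers for an effect already at smaller amounts), compound 1 gives < 5020 nM, which is a limit of the assay rather than a number.
Compound 2 `c1cnc(-c2ccccc2OCC2=NCCN2)nc1`: in this assay compound 2 gives < 100000 nM, again a limit of the assay and not a number.

Compound 2 therefore stands at a limit only; its true effect in this assay is not pinned down, (the limit of < 100000 nM in this assay, at which 1 of the 2 values shown sits). For the measured compounds named here, the other measured value, for compound 1, is also a limit, (the limit of < 5020 nM in this assay, at which 1 of the 2 values shown sits), so no step between measured compounds can be drawn, and the two values cannot be set in order against each other.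

Compound 3 `c1ccc(-c2ccoc2)c(OCC2=NCCN2)c1` has not yet been measured. It differs from compound 2 in one place: furan-3-yl in place of pyrimidin-2-yl on an aromatic carbon.

With compound 2 known only as a limit, the expected step in this assay is a step that the limit leaves unreadable from compound 2 to compound 3, and its direction cannot be read from the measured compounds; it is an estimate resting on the two limits alone. Compound 3 is expected to give about 3000 nM in this assay, with a range from 300 nM to 30000 nM, and a real chance that only a limit is reported.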

Compound 3, half-maximal effective concentration: 5.01 nM
Compound 3: the middle estimate sits 600-fold (2.78 log units) above what was measured; measured number outside the range, below it.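

No step from compound 2 to compound 3 can be read in this assay, because compound 2 is known only as a limit of the assay and not as a number: the limit of < 100000 nM in this assay, at which 1 of the 3 values shown sits.

The compounds shown leave open how large the effect of furan-3-yl in place of pyrimidin-2-yl on an aromatic carbon is, and in which direction it runs.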